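A few compounds are considered here, and "the series" means these few. Any claim that something is new, unique, unknown or untested is made for them only; others in the source may bear on it.

Measured compounds:
- compound 1, `N#Cc1ccc(-c2ccc(Cl)c(C(=O)NCC3(O)CCCCCC3)c2)nc1`: 134 nM
- compound 2, `COc1ccc(-c2ccc(Cl)c(C(=O)NCC3(O)CCCCCC3)c2)nc1`: 213 nM
- compound 3, `Cc1cnc(-c2ccc(Cl)c(C(=O)NCC3(O)CCCCCC3)c2)cn1`: 22 nM

In a functional assay on HEK293 cells for antagonist activity at P2X purinoceptor 7 (Homo sapiens) (a higher number here means a weaker inhibitor, a lower number a stronger inhibitor), compound 2 gives the highest of the three numbers. Its nearest neighbour is compound 1, with a 1.6-fold higher number from compound 1 to compound 2 (0.20 log units; within the scatter), a step within the scatter, so the two cannot be ordered. Compound 3 stands furthest away, with a 9.7-fold lower number from compound 2 to compound 3 (0.99 log units; beyond the scatter) and, from the other side, a 6.1-fold lower number from compound 1 to compound 3 (0.78 log units; beyond the scatter), both beyond the scatter.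

Compound 4, `Cc1ccc(-c2ccc(Cl)c(C(=O)NCC3(O)CCCCCC3)c2)nn1`, is not yet measured. It differs from compound 2 in one place: 6-methylpyridazin-3-yl in place of 5-methoxypyridin-2-yl on an aromatic carbon

The step that bears most directly on this change is a 9.7-fold lower number from compound 2 to compound 3 (0.99 log units; beyond the scatter), where a methyl-bearing diazine took the place of the same 5-methoxypyridin-2-yl group. For the measured compounds named here, the entering 6-methylpyridazin-3-yl group is also a methyl-bearing diazine, though a different one, and no measured step tells how the two diazines compare. Compound 4 is therefore expected to give a lower number than compound 2, by a 4.3-fold lower number from compound 2 to compound 4 (0.63 log units; beyond the scatter), with some allowance for the untested ring. The estimate for compound 4 is 50 nM, in the range 15 nM to 160 nM.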

Compound 4, half-maximal inhibitory concentration: 18 nM
Compound 4: middle estimate off by 2.8-fold (0.44 log units), on the high side; the range from low to high includes it.
By their numbers in this assay, from the lowest: compounds 4 and 3 (each within the scatter of the next); then compounds 1 and 2 (each within the scatter of the next).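

Compound 4 shows that the gain seen with compound 3 is not tied to one diazine, as the 6-methylpyridazin-3-yl group also gives a clear drop from the 5-methoxypyridin-2-yl group (a 12-fold lower number from compound 2 to compound 4 (1.07 log units; beyond the scatter)) and from the 5-cyanopyridin-2-yl group (a 7.4-fold lower number from compound 1 to compound 4 (0.87 log units; beyond the scatter)). The two methyl-bearing diazines cannot be ordered (a 1.2-fold lower number from compound 3 to compound 4 (0.09 log units; within the scatter)), so at this place in this assay the arrangement of the two ring nitrogens makes no difference that can be read. Nothing at hand accounts for the difference between the diazines and the substituted pyridines.

The compounds shown leave open whether the lower numbers go with the second ring nitrogen or with the methyl, as the two always enter together here. From the compounds shown here alone, a 5-methylpyridin-2-yl group or an unsubstituted pyridazin-3-yl group would separate them, and the effect of an amine or a methoxy group on the pyridazine ring also remains open.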